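Fluoro for methyl on the pendant aryl ring

The compounds below may be only part of what the source reports. "The series", "measured", "known", "first", "only" and "open" are said of these compounds alone.

Compound 1 `Cc1ccccc1C[C@H]1C(=O)OC[C@@H]1Cc1ccccc1` and compound 2 `O=C1OC[C@H](Cc2ccccc2)[C@H]1Cc1ccccc1F` share one core; compound 3 `Cc1cccc(C[C@H]2COC[C@@H]2Cc2ccc(Cl)c(Cl)c2)c1` and compound 4 `Fc1cccc(C[C@H]2COC[C@@H]2Cc2ccc(Cl)c(Cl)c2)c1` share another, and the difference between the two cores is not broken down here. In a functional assay on HL-60 cells (Homo sapiens) for cytotoxicity, read by WST assay, with a stated time of 48 h (a higher number here means that more compound is needed for the effect, a lower number that less compound is needed), compound 1 gives 57000 nM, compound 2 gives 72000 nM and compound 3 gives 28000 nM. In compound 2 against compound 1 the change is fluoro in place of methyl on an aromatic carbon. Its measured step was a 1.3-fold higher number from compound 1 to compound 2 (0.10 log units; within the scatter). Compound 4 against compound 3 carries fluoro in place of methyl on an aromatic carbon, the same kind of change, but the place reads meta to a large group rather than ortho to a large group. The expected step is a 1.1-fold higher number from compound 3 to compound 4 (0.06 log units; within the scatter), small, because a 1.3-fold higher number from compound 1 to compound 2 (0.10 log units; within the scatter) lay within the scatter, with the caveat that the place differs. For compound 4 the estimate is 32000 nM, with a range from 15000 nM to 70000 nM.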

Compound 4, half-maximal effective concentration: 20000 nM
Compound 4: the middle estimate sits 1.6-fold (0.20 log units) above what was measured; the range from low to high includes it.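

In this assay the new step is a 1.4-fold lower number from compound 3 to compound 4 (0.15 log units; within the scatter), so fluoro in place of methyl leaves this pair within the scatter of each other. Set beside the earlier step, the change reads the same on both cores, with no difference that can be told apart: the same change on two cores in this assay, a 1.3-fold higher number (0.10 log units; within the scatter) from compound 1 to compound 2 and a 1.4-fold lower number (0.15 log units; within the scatter) from compound 3 to compound 4, 1.8-fold (0.25 log units) apart, within the scatter of two such steps The opposite signs of the two steps therefore carry no meaning, but this does not show that the change is neutral on other cores, and the place on the ring is not the same in the two pairs.

Open, on these data alone, is whether a nitrile or a methoxy at the same place would give a step beyond the scatter in this assay. Also open, as far as these compounds go, is how the two cores compare with the aryl groups held the same.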